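Notes on chloro in place of hydrogen from compound 2

The compounds below may be only part of what the source reports. "The series", "measured", "known", "first", "only" and "open" are said of these compounds alone.

Compound 2 `CN1CCN(c2nc(-c3cccc(Cl)c3)nc3[nH]cnc23)CC1` carries a 3-chlorophenyl group on the shared core. In an assay on cells for displacement of a labelled ligand from adenosine receptor A1 (Homo sapiens), read by scintillation counting and radioligand binding, with a stated time of 60 min, tested at 10 uM (a higher number here means more inhibition at the concentration tested (going by the name of the read-out), a lower number less inhibition), compound 2 gives > 80%, which is a limit of the assay and not a number. Compound 1 `CN1CCN(c2nc(-c3ccc(Cl)c(Cl)c3)nc3[nH]cnc23)CC1` gives > 80% in this assay, likewise a limit. Compound 3 `CN1CCN(c2nc(-c3ccc(Cl)c(C(F)(F)F)c3)nc3[nH]cnc23)CC1` gives 52.4% in this assay. Compound 4 `CN1CCN(c2nc(-c3cc(Cl)ccc3Cl)nc3[nH]cnc23)CC1` has not been measured; it differs from compound 2 by chloro in place of hydrogen on an aromatic carbon. Among the compounds with values here, no measured step adds chloro in place of hydrogen. The nearest is a step that the two limits leave unreadable from compound 1 to compound 2, a change of the reverse kind at another position, while a number at least 27.6 percentage points lower from compound 1 to compound 3 (beyond the scatter) concerns trifluoromethyl. Compound 1 and compound 2 both sit at the limit of > 80% in this assay, at which 2 of the 3 values shown sit. For compound 4 a small step, or none beyond the scatter, is expected, a number at least 5 percentage points lower from compound 2 to compound 4 (that floor lies within the scatter). Compound 4 is therefore estimated at 75%, between 45% and 90%.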

Compound 4, a percentage reported as inhibition, at one concentration (the size of the read-out at that concentration, not a potency): > 80%
Compound 4: a limit, no number; the forecaster's own chance of this, stated with the estimate: 45%; middle value at least 5 percentage points away from the limit.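

In this assay compound 4 gives > 80%, a limit and not a number. Within the data shown here, compound 1 and compound 2 also stand at limits, so no step to compound 4 can be read. From the compounds shown here alone, whether these three compounds differ at all in this assay stays open.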